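The source may hold more compounds than are shown below. What is called first, only, known or untested is meant among the compounds shown, and "the series" means these compounds.

Of the compounds shown here, two with a shared core have been measured. Compound 1, `NC(=O)Cn1c(=O)n(C2OC(CO)[C@@H](O)[C@H]2O)c2nc(N)nc(O)c21`, carries a sugar on one ring nitrogen and a carbamoylmethyl on the other. Compound 2, `C=CCn1c(=O)n(CCCC)c2nc(N)nc(O)c21`, has an allyl and a butyl in those places instead. In a functional assay on the whole organism with Mus musculus as the target (a higher number here means a larger maximal response, a lower number a smaller maximal response), compound 1 gives 72%, and in this assay compound 2 gives 36%. Compound 1 thus stands highest of the two values, with compound 2 lower by a gap beyond the usual scatter. Among the compounds with values here, no single-change step between the two measured compounds exists, so how much of that gap belongs to either side of the core cannot be told from the numbers.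

Compound 3, `CCCCCCn1c(=O)n(C2OC(CO)[C@@H](O)[C@H]2O)c2nc(N)nc(O)c21`, keeps the sugar of compound 1 and differs from it by pentyl in place of carbamoyl on a saturated chain carbon bound to an aromatic nitrogen. Within the data shown here, the only guidance is that the more alkyl-bearing compound 2 reads lower in this assay than compound 1. On that basis the step of a number 20 percentage points lower from compound 1 to compound 3 (beyond the scatter) is expected to be a moderate drop, possibly beyond the scatter, though the evidence is thin. Compound 3 is therefore estimated at 52% in this assay, within a range from 28% to 78%.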

Compound 3, largest response reached (reported as maximal response), in percent of the reference or control that the assay uses: 11%
Beside the measured number, compound 3's estimate is 41 percentage points above it; the whole stated range lies above it.
By their numbers in this assay, from the lowest: compound 3; then compound 2; then compound 1.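

Within the data shown here, with the sugar held fixed, this is the first comparison in which only one place changes, and in this assay the exchange on a saturated chain carbon bound to an aromatic nitrogen gives a number 61 percentage points lower from compound 1 to compound 3 (beyond the scatter). This shows that the group at this position can by itself move the maximal response by a large amount, which the earlier pair, differing in two places, could not show. The exchange replaces carbamoyl, with its hydrogen-bond donor and acceptor, by pentyl, which has neither, but no measurement on hand explains why the response falls.

Among these compounds, the single step changes both the end group and the length of the chain, so it leaves open whether the carbamoyl itself or the size of the hexyl chain matters more, a question that a short ethyl group or a hexyl chain ending in a carboxylic acid or an amine would help to separate. It also leaves open whether carbamoylmethyl and hexyl would differ as widely on a core that carries butyl in place of the sugar.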